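Swapping the aryl group on a shared chromone-like core

A few compounds are considered here, and "the series" means these few. Any claim that something is new, unique, unknown or untested is made for them only; others in the source may bear on it.

Compound 1 `CCOc1ccc(-c2cc(=O)c3c(o2)C(CC)(CC)C(=O)C(CC)=C3O)cc1`: 7.54 uM
Compound 2 `CCC1=C(O)c2c(oc(-c3ccccc3F)cc2=O)C(CC)(CC)C1=O`: 3.93 uM

Both measured compounds share one core and differ only in the aromatic group attached to it. In a functional assay on KBVIN cells (Homo sapiens) for antiproliferative activity, read by sulforhodamine B assay, with a stated time of 3 days (a higher number here means that more compound is needed for the effect, a lower number that less compound is needed), compound 1 gives 7.54 uM and compound 2 gives 3.93 uM. Among the compounds with values here, the single measured step, a 1.9-fold lower number from compound 1 to compound 2 (0.28 log units; within the scatter), is within the scatter, so the two numbers cannot be told apart with confidence, and compound 2 simply has the lower of the two values without being called the stronger one.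

Compound 3 `CCC1=C(O)c2c(oc(-c3ccc(O)c(O)c3)cc2=O)C(CC)(CC)C1=O` is the next compound on the same core. 3,4-dihydroxyphenyl in place of 2-fluorophenyl on an aromatic carbon This change replaces a ring carrying a single fluorine with a ring carrying two hydroxyl groups. Within the data shown here, the only step in hand, a 1.9-fold lower number from compound 1 to compound 2 (0.28 log units; within the scatter), concerns a different swap of aryl group and was within the scatter, so it gives little guidance beyond suggesting that changes at this position have so far stayed modest. The step from compound 2 to compound 3 is therefore expected to be small, a 1.4-fold higher number from compound 2 to compound 3 (0.15 log units; within the scatter), in this assay. Compound 3 is expected to give about 5.5 uM, within a range of 1.5 uM to 20 uM.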

Compound 3, concentration for half-maximal effect: 5.41 uM
Compound 3: the middle estimate sits 1.0-fold (0.01 log units) above what was measured; low and high end bracket the measured number.
By their numbers in this assay, from the lowest: compounds 2, 3 and 1 (each within the scatter of the next).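

Counted from the structures, 3,4-dihydroxyphenyl brings 2 hydrogen-bond donors and 2 hydrogen-bond acceptors where 2-fluorophenyl has 0 of each, yet in this assay this swap amounts to a 1.4-fold higher number from compound 2 to compound 3 (0.14 log units; within the scatter). Measured against the 4-ethoxyphenyl group, the same ring gives a 1.4-fold lower number from compound 1 to compound 3 (0.14 log units; within the scatter), so the three aryl groups tried on this aromatic carbon, next to the ring oxygen, give numbers that cannot be told apart in this assay, even though they differ clearly in what they carry. No measurement is at hand that would explain this outcome.

As far as these compounds go, all three compounds carry a substituted phenyl ring at this place, so it remains open whether a different kind of group, such as an amine or a carboxylic acid on that ring, or a plain alkyl chain in place of the ring, would give a step beyond the scatter. Also open, from the compounds shown here alone, is whether altering the ethyl groups on the shared core would matter more in this assay than swapping the aryl group does.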